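The source may report more compounds than this note shows. Statements on the series, on what has been measured and on what is new or still open speak of the compounds shown alone.

In a functional assay on ECa-109 cells (Homo sapiens) for inhibition, read by MTT assay, with a stated time of 72 h (a higher number here means a weaker inhibitor, a lower number a stronger inhibitor), compound 2 `N#Cc1c(Nc2cccc(Cl)c2)nc(SCc2cn(Cc3ccccc3Cl)nn2)nc1-c1ccccc1` gives 24400 nM, numerically the top of the two numbers shown; compound 1 `C#CCSc1nc(Nc2ccc(OC)cc2)c(C#N)c(-c2ccccc2)n1` gives 23200 nM in this assay, and the gap between the two lies within the scatter, so it sets no order. Compound 3 `N#Cc1c(Nc2ccc(F)cc2)nc(SCc2cn(Cc3ccccc3Cl)nn2)nc1-c1ccccc1` differs from compound 2 in one place: 4-fluorophenyl in place of 3-chlorophenyl on a nitrogen on an aromatic ring. Going by the values given here, no measured pair shows this change, so the step expected in this assay, a 1.1-fold lower number from compound 2 to compound 3 (0.04 log units; within the scatter), is estimated as none beyond the scatter. Compound 3 is accordingly expected to give 22000 nM in this assay, with a range of 7000 nM to 70000 nM.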

Compound 3, half-maximal inhibitory concentration: 25800 nM
Beside the measured number, compound 3's estimate is 1.2-fold (0.07 log units) below it; the range from low to high includes it.
By their numbers in this assay, from the lowest: compounds 1, 2 and 3 (each within the scatter of the next).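

In this assay, 4-fluorophenyl in place of 3-chlorophenyl on the nitrogen gives a 1.1-fold higher number from compound 2 to compound 3 (0.02 log units; within the scatter), so this exchange of one halogen-bearing phenyl for another leaves no readable change at this position. The halogen and its place on the phenyl change together here, so the two cannot be read apart. Nothing measured on these groups bears on the result.

Still open, on these data alone, is whether any group on this nitrogen moves the number beyond the scatter, for instance a phenyl carrying a carboxylic acid or a dimethylamino group, or a cyclohexyl in place of the phenyl.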